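Three Limits and a Dichlorophenyl Question

A few compounds are considered here, and "the series" means these few. Any claim that something is new, unique, unknown or untested is made for them only; others in the source may bear on it.

Compound 3 `CCC(COc1cccc(C)c1)OC(=O)NCc1ccccc1`: > 100000 nM
Compound 1 `CCC(COc1cccc(Cl)c1)OC(=O)NCc1ccccc1`: > 100000 nM
Compound 2 `CCC(COc1cccc(C#N)c1)OC(=O)NCc1ccccc1`: > 100000 nM

In an assay for inhibition of zeta-carotene desaturase, chloroplastic/chromoplastic (Capsicum annuum), using a Dixon plot, with a stated time of 8 h (on this read-out higher numbers stand for weaker inhibition and lower numbers for stronger inhibition), compound 3 gives > 100000 nM, which is a limit of the assay and not a number. Compound 1 likewise gives > 100000 nM, a limit. Compound 2 gives > 100000 nM, also a limit. All three values therefore sit at the limit of > 100000 nM in this assay, at which 3 of the 3 values shown sit, and where compound 3 stands relative to the others cannot be said.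

Compound 4 `CCC(COc1cccc(Cl)c1Cl)OC(=O)NCc1ccccc1` has not yet been tested. It differs from compound 3 by 2,3-dichlorophenyl in place of 3-methylphenyl on an oxygen on a saturated carbon. The measured steps that bear on this change are a step that the two limits leave unreadable from compound 1 to compound 3, a step that the two limits leave unreadable from compound 2 to compound 3 and a step that the two limits leave unreadable from compound 1 to compound 2; none of them has a readable size, so they give no direction for the move to a dichlorophenyl.

With nothing but limits to build on, compound 4 is expected to stay near the same limit, and the step that the limit leaves unreadable from compound 3 to compound 4 is estimated to be small. Compound 4 is expected to give about 120000 nM, in a range from 20000 nM to 1000000 nM.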

Compound 4, half-maximal inhibitory concentration: > 100000 nM
Compound 4: only a limit was reported (the forecaster's own chance of this, stated with the estimate: 85%); the middle value does not contradict the limit.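

Compound 4 also ends at a limit of the assay, like compound 1, compound 2 and compound 3, so no step among these four compounds can be read: the limit of > 100000 nM in this assay, at which 4 of the 4 values shown sit. Whether any group shown on the aromatic ring gives a measurable value in this assay stays open.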